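This account rests on a few compounds, and the source may have more. Where it says the series, first, only, none or still open, it means among the compounds named here.

In a functional assay on OVCAR-8 cells (Homo sapiens) for inhibition, read by sulforhodamine B assay, with a stated time of 48 h, tested at 0.01 uM (on this read-out higher numbers stand for a weaker effect at the one concentration tested and lower numbers for a stronger effect), compound 1 `O=C(Nc1cccc(-n2cc(-c3ccncc3)c(-c3cc(O)cc(Cl)c3)n2)c1)Nc1ccc(Cl)c(C(F)(F)F)c1` gives 102%. Among the compounds with values here, compound 2 `O=C(Nc1cccc(-n2cc(-c3ccncc3)c(-c3cc(O)cc(Cl)c3)n2)c1)Nc1ccc(Cl)c(Cl)c1` gives 102% in this assay, and the step of no change at the digits printed from compound 1 to compound 2 (within the scatter) is the only one-place change among the measured compounds. Compound 3 `COc1cc(Cl)cc(-c2nn(-c3cccc(NC(=O)Nc4cc(C(F)(F)F)cc(C(F)(F)F)c4)c3)cc2-c2ccncc2)c1` gives 99% in this assay; its number differs from those of compound 1 and compound 2 by amounts that fall within the usual scatter, so the three measured compounds cannot be told apart on this read-out, and none of them shows a marked effect at the concentration tested.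

Compound 4 `COc1cc(Cl)cc(-c2nn(-c3cccc(NC(=O)Nc4cccc(C(F)(F)F)c4)c3)cc2-c2ccncc2)c1` is the next compound, and it differs from compound 3 as follows: hydrogen in place of trifluoromethyl on an aromatic carbon. Within the data shown here, the one measured step that bears on it, which also removed a trifluoromethyl group from an aromatic carbon, is no change at the digits printed from compound 1 to compound 2 (within the scatter), a step of no size beyond the scatter. Compound 4 is therefore expected to show a step of a number 1 percentage points higher from compound 3 to compound 4 (within the scatter) in this assay, with no change beyond the scatter. The expected value of compound 4 is 100%, with a range from 90% to 110%.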

Compound 4, a percentage reported as activity, at one concentration (the size of the read-out at that concentration, not a potency): 97%
Beside the measured number, compound 4's estimate is 3 percentage points above it; low and high end bracket the measured number.
By their numbers in this assay, from the lowest: compounds 4, 3, 1 and 2 (each within the scatter of the next).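

In this assay the change to hydrogen gives a number 2 percentage points lower from compound 3 to compound 4 (within the scatter), so this aromatic carbon can lose its trifluoromethyl group outright and the read-out shows no shift beyond the scatter. The earlier one-place step had only put chloro in place of trifluoromethyl, whereas here no heavy atom enters, and the second trifluoromethyl group of compound 3 remains in compound 4. No measurement shown accounts for this result.

The compounds shown leave open whether an amine or a carboxylic acid on this aromatic carbon would move the read-out beyond the scatter. They also leave open whether hydrogen in place of the remaining trifluoromethyl group of compound 4 would do so, and whether this step would look the same at any other concentration.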